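The source may report more compounds than this note shows. Statements on the series, on what has been measured and on what is new or still open speak of the compounds shown alone.

Four compounds share one core and differ in two places. Compound 2 `CSc1ncnc2c1c(-c1ccoc1)cn2[C@@H]1O[C@H](CO)[C@@H](O)[C@H]1O` carries a methylsulfanyl group and a furan-3-yl group. Compound 1 `CN(C)c1ncnc2c1c(-c1ccoc1)cn2[C@@H]1O[C@H](CO)[C@@H](O)[C@H]1O` has dimethylamino in place of methylsulfanyl, and compound 3 `CSc1ncnc2c1c(-c1cccs1)cn2[C@@H]1O[C@H](CO)[C@@H](O)[C@H]1O` has thiophen-2-yl in place of furan-3-yl. Compound 4 `CN(C)c1ncnc2c1c(-c1cccs1)cn2[C@@H]1O[C@H](CO)[C@@H](O)[C@H]1O` holds both changes at once and has not yet been measured.

In a functional assay on HCT-116 cells (Homo sapiens), read by MTT assay, with a stated time of 72 h (a higher number here means a weaker inhibitor, a lower number a stronger inhibitor), compound 2 gives 40 nM. In this assay compound 1 gives only a limit of the assay, > 20000 nM. In this assay compound 3 likewise gives only a limit, > 20000 nM. The change dimethylamino in place of methylsulfanyl on an aromatic carbon produces an at least 500-fold higher number from compound 2 to compound 1 (2.69 log units; beyond the scatter). The switch of the second group produces an at least 500-fold higher number from compound 2 to compound 3 (2.69 log units; beyond the scatter). Both steps stop at the limit of > 20000 nM in this assay, at which 2 of the 3 values shown sit, so their full size is not known.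

Compound 4 differs from compound 3 by dimethylamino in place of methylsulfanyl on an aromatic carbon, the same change as from compound 2 to compound 1, made on a core that differs by thiophen-2-yl in place of furan-3-yl on an aromatic carbon. Since that change already cost an at least 500-fold higher number from compound 2 to compound 1 (2.69 log units; beyond the scatter) on the other core, the step is expected to be a number no higher from compound 3 to compound 4 (the limit leaves the size open). Compound 4 is estimated at 20000 nM, most likely again only a limit.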

Compound 4, half-maximal inhibitory concentration: > 20000 nM
Compound 4: only a limit was reported; the forecaster's own chance of this, stated with the estimate: 85%; the middle value sits exactly at the limit.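

Compound 4 also gives only a limit in this assay, and so do compound 1 and compound 3, so the steps from compound 3 and from compound 1 to compound 4 cannot be read: the limit of > 20000 nM in this assay, at which 3 of the 4 values shown sit.

The compounds shown leave open how far compound 1, compound 3 and compound 4 truly differ from one another in strength.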